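Swapping the Side Group on a Compound at the Limit

The compounds below may be only part of what the source reports. "The series", "measured", "known", "first", "only" and "open" are said of these compounds alone.

In a functional assay on U-251 cells (Homo sapiens) for antiproliferative activity, read by MTT assay, with a stated time of 24 h (a lower number here means a stronger inhibitor, a higher number a weaker inhibitor), compound 1 `C#CCOc1ccc2c(=O)c(-c3cc(OC)c(OC)cc3OC)coc2c1` gives 6450 nM. Compound 2 `COc1cccc(C(=O)Oc2ccc3c(=O)c(-c4cc(OC)c(OC)cc4OC)coc3c2)c1` reads > 10000 nM, which is a limit and not a number. Compound 3 `COc1cc(OC)c(-c2coc3cc(OCC(=O)c4cccc(C(F)(F)F)c4)ccc3c2=O)cc1OC` reads > 10000 nM, also a limit, and so stands at the limit of > 10000 nM in this assay, at which 2 of the 3 values shown sit.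

Compound 4 `COc1cc(OC)c(-c2coc3cc(OCc4ccc(C#N)cc4)ccc3c2=O)cc1OC` differs from compound 3 in one place: 4-cyanophenyl in place of (3-(trifluoromethyl)phenyl)carbonyl on a saturated chain carbon bound to an oxygen on an aromatic ring. The leaving and entering groups each hold one six-membered aromatic ring of carbon only. Within the data shown here, two measured steps bear on this change: an at least 1.5-fold higher number from compound 1 to compound 2 (0.19 log units; that floor lies within the scatter), and an at least 1.5-fold higher number from compound 1 to compound 3 (0.19 log units; that floor lies within the scatter). Both of those steps put such a ring into the side group, so compound 4 is expected to stay near the limit.

The expected step is a number no higher from compound 3 to compound 4 (the limit leaves the size open), with no change beyond the scatter expected. For compound 4 the estimated value is 10000 nM, within an expected range from 4000 nM to 25000 nM.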

Compound 4, half-maximal inhibitory concentration: 6180 nM
Compound 4: middle estimate off by 1.6-fold (0.21 log units), on the high side; the measured number falls inside the stated range.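

A six-membered aromatic ring in the side group does not by itself force a limit reading in this assay, which compounds 2 and 3 alone could not show, as both sit at the limit: the limit of > 10000 nM in this assay, at which 2 of the 4 values shown sit. Starting from those limits, the steps give only floors: an at least 1.6-fold lower number from compound 3 to compound 4 (0.20 log units; that floor lies within the scatter) and an at least 1.6-fold lower number from compound 2 to compound 4 (0.20 log units; that floor lies within the scatter). Against the small propargyl side group, the ring costs nothing measurable: a 1.0-fold lower number from compound 1 to compound 4 (0.02 log units; within the scatter).

The compounds shown do not separate the nitrile from the loss of the carbonyl, which change together. Going by these compounds, how an amine or a carboxylic acid in place of the nitrile would read stays open.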